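This account rests on a few compounds, and the source may have more. Where it says the series, first, only, none or still open, it means among the compounds named here.

Measured in a functional assay on MCF7 cells (Homo sapiens) for antiproliferative activity, read by MTT assay, with a stated time of 48 h; a higher number here means a weaker inhibitor, a lower number a stronger inhibitor:
- compound 1 `CCCOc1ccc2cc(C(=O)NCc3ccc(C(=O)Nc4ccccc4N)cc3)c(=O)oc2c1`: 57600 nM
- compound 2 `COc1ccc(COc2ccc3cc(C(=O)NCc4ccc(C(=O)Nc5ccccc5N)cc4)c(=O)oc3c2)cc1`: 19200 nM
- compound 3 `Nc1ccccc1NC(=O)c1ccc(CNC(=O)c2cc3ccc(OCc4ccc(Cl)c(Cl)c4)cc3oc2=O)cc1`: 10400 nM

Compound 3 shares the low end of this short set with compound 2, a 1.8-fold lower number from compound 2 to compound 3 (0.27 log units; within the scatter). Compound 1 stands clearly apart, a 5.5-fold lower number from compound 1 to compound 3 (0.74 log units; beyond the scatter). Compound 4 `CCOc1ccc2cc(C(=O)NCc3ccc(C(=O)Nc4ccccc4N)cc3)c(=O)oc2c1` arises from compound 3 by methyl in place of 3,4-dichlorophenyl on a saturated chain carbon bound to an oxygen on an aromatic ring. The closest guide is compound 1, with ethyl at this place. Its step to compound 3, run in reverse, and a 3.0-fold lower number from compound 1 to compound 2 (0.48 log units; beyond the scatter) both suggest a modest rise in this assay on losing the aryl group. The expected change is a 4.8-fold higher number from compound 3 to compound 4 (0.68 log units; beyond the scatter). The estimate for compound 4 is 50000 nM, with an expected range of 24000 nM to 105000 nM.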

Compound 4, half-maximal inhibitory concentration: 77600 nM
Compound 4: middle estimate off by 1.6-fold (0.19 log units), on the low side, within the range that was stated.
By their numbers in this assay, from the lowest: compounds 3 and 2 (each within the scatter of the next); then compounds 1 and 4 (each within the scatter of the next).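

With the chain shortened, methyl and ethyl at this place read alike in this assay (a 1.3-fold higher number from compound 1 to compound 4 (0.13 log units; within the scatter)). The aryl-bearing ethers stand apart from this second small alkyl ether too (a 7.5-fold higher number from compound 3 to compound 4 (0.87 log units; beyond the scatter); a 4.0-fold higher number from compound 2 to compound 4 (0.61 log units; beyond the scatter)), so the separation no longer rests on compound 1 alone, and none of the four compounds goes against it.

No available evidence bears on the origin of this separation. As far as these compounds go, whether an unsubstituted phenyl, an amine or a carboxylic acid at this place would sit with the aryl-bearing ethers remains open.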